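The compounds below may be only part of what the source reports. "The series", "measured", "known", "first", "only" and "open" are said of these compounds alone.

Measured in an ADME assay on Vero cells (Chlorocebus sabaeus) for cytotoxicity, read by reporter gene assay, with a stated time of 4 days; on this read-out lower numbers stand for stronger inhibition and higher numbers for weaker inhibition:
- Compound 1 `CCCC(C)C(=O)OCC(C)(C)CC1=C(O)C(=O)c2ccccc2C1=O`: 120 nM
- Compound 2 `CCCCCCCC(=O)OCC(C)(C)CC1=C(O)C(=O)c2ccccc2C1=O`: > 258000 nM, a limit of the assay
- Compound 3 `CCCCCCCCCC(=O)OCC(C)(C)CC1=C(O)C(=O)c2ccccc2C1=O`: 203000 nM

Of the two actual numbers, compound 3 has the higher, far from compound 1. Compound 4 `CCCCCCCCCCCCCCCC(=O)OCC(C)(C)CC1=C(O)C(=O)c2ccccc2C1=O` differs from compound 3 by hexyl in place of hydrogen on a saturated chain carbon, nine bonds along the chain from a carbonyl carbon, with hexyl in place of hydrogen on a saturated chain carbon, nine bonds along the chain from a carbonyl carbon.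

The large steps of an at least 2100-fold higher number from compound 1 to compound 2 (3.33 log units; beyond the scatter) and a 1700-fold higher number from compound 1 to compound 3 (3.23 log units; beyond the scatter) replaced 1-methylbutyl, a different change. Within the data shown here, the closest precedent, also a chain extension, is an at least 1.2-fold lower number from compound 2 to compound 3 (0.10 log units; that floor lies within the scatter). No step beyond the scatter is therefore expected in this assay, and only a limit may be reported. The expected step is a 1.2-fold lower number from compound 3 to compound 4 (0.08 log units; within the scatter). For compound 4 the estimated value is 170000 nM, with an expected range of 70000 nM to 280000 nM.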

Compound 4, half-maximal inhibitory concentration: 4410 nM
For compound 4 the middle estimate is 39-fold (1.59 log units) above the measured one; the measured number lies below the stated range.
By their numbers in this assay, from the lowest: compound 1; then compound 4; then compound 3. At a limit, above all of these: compound 2.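

In this assay, extending the straight chain does shift the number at this place, on a saturated chain carbon nine bonds along the chain from a carbonyl carbon: hexyl in place of hydrogen gives a 46-fold lower number from compound 3 to compound 4 (1.66 log units; beyond the scatter), although the earlier extension showed no step beyond the scatter. Measured from the shorter chain, the change is an at least 58-fold lower number from compound 2 to compound 4 (1.76 log units; beyond the scatter). Compound 2 stands at a limit, so this step is only a floor: the limit of > 258000 nM in this assay, at which 1 of the 4 values shown sits. The compounds shown leave open whether a longer chain would lower the number further, and what an amine in place of hexyl would give.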